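Two Fluorines in Place of Two Chlorines

The source may report more compounds than this note shows. Statements on the series, on what has been measured and on what is new or still open speak of the compounds shown alone.

Compound 2 `COc1cc(-c2cc(/C=C/C(=O)c3ccc(Cl)c(Cl)c3)[nH]n2)cc(OC)c1OC` gives 9% in a functional assay on CCRF-CEM cells (Homo sapiens) for cytotoxicity, read by sulforhodamine B assay, with a stated time of 48 h, tested at 10 uM (a lower number here means a stronger effect, a higher number a weaker effect of the compound at the concentration tested), the highest of the two numbers measured here. For the measured compounds named here, compound 1 `COc1ccc(-c2cc(/C=C/C(=O)c3ccc(N)cc3)[nH]n2)cc1` gives -27% in this assay, a number standing beyond the scatter below compound 2; the two differ in more than one place, so no single step between them is counted. Compound 3 `COc1cc(-c2cc(/C=C/C(=O)c3ccc(F)c(F)c3)[nH]n2)cc(OC)c1OC` carries 3,4-difluorophenyl in place of 3,4-dichlorophenyl on a carbonyl carbon. Going by the values given here, no measured step covers a change of this kind. For compound 3 the step of a number 4 percentage points lower from compound 2 to compound 3 (within the scatter) is expected to stay within the scatter. Compound 3 is therefore estimated at 5%, within -25% to 30%.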

Compound 3, a percentage reported as activity, at one concentration (the size of the read-out at that concentration, not a potency): 7%
Estimate against measurement, compound 3: 2 percentage points below; low and high end bracket the measured number.
By their numbers in this assay, from the lowest: compound 1; then compounds 3 and 2 (each within the scatter of the next).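

In this assay, for the compounds shown here, the first comparison here that differs in one place gives a number 2 percentage points lower from compound 2 to compound 3 (within the scatter), so at this position, on a carbonyl carbon, 3,4-difluorophenyl and 3,4-dichlorophenyl cannot be told apart. This holds for this one pair, on this core and at this single concentration. Nothing at hand explains the result. As far as these compounds go, what a nitrile or a carboxylic acid on this phenyl ring would do stays open. So does whether 3,4-difluorophenyl would read the same on the core of compound 1.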